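Methyl for Methoxy on the Benzyl Group of Compound 3

A few compounds are considered here, and "the series" means these few. Any claim that something is new, unique, unknown or untested is made for them only; others in the source may bear on it.

Measured so far, in an ADME assay on isolated protein for inhibition of Amine oxidase [flavin-containing] A (Homo sapiens), read by fluorescence and Amplex Red, with stated times of 15 min and 20 min; a higher number here means a weaker inhibitor, a lower number a stronger inhibitor:
Compound 1 `C#CCN(CCCCOc1ccc2ccc(=O)oc2c1)Cc1ccc(OC)cc1` gives 54500 nM.
Compound 2 `C#CCN(CCCCOc1ccc2ccc(=O)oc2c1)Cc1cccc(OC)c1` gives 78600 nM.
Compound 3 `C#CCN(CCCOc1ccc2ccc(=O)oc2c1)Cc1ccc(OC)cc1` gives 60000 nM.

Compound 3 gives the second highest of the three numbers. Its value and that of compound 1 lie within the scatter of each other, and so do its value and that of compound 2. Within the data shown here, the only step between measured compounds moves the methoxy around the ring: a 1.4-fold higher number from compound 1 to compound 2 (0.16 log units; within the scatter).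

Compound 4 `C#CCN(CCCOc1ccc2ccc(=O)oc2c1)Cc1ccc(C)cc1` differs from compound 3 by a single change: methyl in place of methoxy on an aromatic carbon. Among the measured compounds shown here, no measured step removes the methoxy oxygen, so the closest guide is the step from compound 1 to compound 2, which stayed within the scatter. That suggests the benzyl substituent is not steering the number here, and a step of similar size, in no firm direction, is expected: no change at the digits printed from compound 3 to compound 4 (within the scatter). Compound 4 is therefore estimated at 60000 nM in this assay, with a plausible range from 25000 nM to 150000 nM.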

Compound 4, half-maximal inhibitory concentration: 116000 nM
The estimate for compound 4 lay 1.9-fold (0.29 log units) below the measured number; measured number inside the range.
By their numbers in this assay, from the lowest: compounds 1, 3, 2 and 4 (each within the scatter of the next, the first and the last beyond it).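

In this assay, methyl in place of methoxy on this aromatic carbon, para to a large group, gives a 1.9-fold higher number from compound 3 to compound 4 (0.29 log units; within the scatter). The earlier step only moved the methoxy around the ring, whereas this one removes its oxygen and the one hydrogen-bond acceptor counted for the group, and the step still does not pass the usual scatter, so these two compounds do not show that the methoxy is needed at this position. No measurement shown here speaks to what lies behind the size of this step.

As far as these compounds go, whether a chlorine atom, a hydroxyl group or a plain hydrogen in the same place would also stay within the scatter of compound 3 remains open. So does whether methyl for methoxy would give a similar step on the longer chain of compound 1.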